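The source may hold more compounds than are shown below. What is called first, only, known or untested is meant among the compounds shown, and "the series" means these compounds.

Compound 2 `Cn1c(=O)c2[nH]c(-c3ccc(S(=O)(=O)N4CCN(c5ccccc5)CC4)cc3)cc2n(C)c1=O` carries the lowest number of the two compounds measured in an assay on HEK293 cells for displacement of a labelled ligand from adenosine receptor A2b (Homo sapiens) (a lower number here means a stronger inhibitor, a higher number a weaker inhibitor), giving 6 nM. Compound 1 `Cn1c(=O)c2[nH]c(-c3ccc(S(=O)(=O)N4CCN(Cc5ccc(F)cc5)CC4)cc3)cc2n(C)c1=O` gives 10 nM in this assay; the step of a 1.7-fold lower number from compound 1 to compound 2 (0.22 log units; within the scatter) lies within the scatter. Compound 3 `Cn1c(=O)c2[nH]c(-c3ccc(S(=O)(=O)N4CCN(Cc5ccncc5)CC4)cc3)cc2n(C)c1=O` differs from compound 2 by (pyridin-4-yl)methyl in place of phenyl on an amine nitrogen in a ring. Going by the values given here, only the step from compound 1 to compound 2 touches this position, and it shows no change beyond the scatter, so for this assay no step beyond the scatter is expected in either direction. Compound 3 is therefore estimated at 10 nM, range 4 nM to 25 nM, an expected step of a 1.7-fold higher number from compound 2 to compound 3 (0.22 log units; within the scatter).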

Compound 3, half-maximal inhibitory concentration: 27 nM
The estimate for compound 3 lay 2.7-fold (0.43 log units) below the measured number; measured number above the stated range.
By their numbers in this assay, from the lowest: compounds 2 and 1 (each within the scatter of the next); then compound 3.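

Going by these compounds alone, the substituent on the amine nitrogen in the ring is not indifferent in this assay: (pyridin-4-yl)methyl in place of phenyl gives a 4.5-fold higher number from compound 2 to compound 3 (0.65 log units; beyond the scatter), the first step at this position beyond the scatter. With the saturated chain carbon kept, pyridin-4-yl in place of 4-fluorophenyl still gives a 2.7-fold higher number from compound 1 to compound 3 (0.43 log units; beyond the scatter), so a change in the aromatic ring alone moves the number. Nothing available explains this rise.

Going by these compounds, whether unsubstituted benzyl would fall with compound 1 or compound 3 remains open. So does whether pyridin-4-yl placed directly on the amine nitrogen would match phenyl.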